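This account rests on a few compounds, and the source may have more. Where it says the series, first, only, none or still open, it means among the compounds named here.

Working notes on the series. In an ADME assay on HepG2 2.2.15 cells (Homo sapiens) for cytotoxicity, read by CCK-8 assay, with a stated time of 8 days (a higher number here means that more compound is tolerated, a lower number that less compound is tolerated), compound 1 (`COc1ccc(-c2cc(NC(=O)c3cccc(OC)c3O)c[nH]c2=O)cc1`) gives 49200 nM. Compound 2 (`COc1ccc(-c2cc(NC(=O)c3ccc(Cl)cc3O)c[nH]c2=O)cc1`) gives 50500 nM, and compound 3 (`Cc1cccc(-c2cc(NC(=O)c3ccc(Cl)cc3O)c[nH]c2=O)c1`) gives 33100 nM. These three values lie within the scatter of one another, so compound 1 is not separated from either of the other two compounds.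

Compound 4 (`CCOc1ccc(-c2cc(NC(=O)c3cccc(OC)c3O)c[nH]c2=O)cc1`) differs from compound 1 by methyl in place of hydrogen on a saturated chain carbon bound to an oxygen on an aromatic ring. The same difference reads as methoxy to ethoxy, or 4-methoxyphenyl to 4-ethoxyphenyl. Going by the values given here, no measured step makes this exact change.

The nearest measured step replaces 4-methoxyphenyl with 3-methylphenyl, and it gives a 1.5-fold lower number from compound 2 to compound 3 (0.18 log units; within the scatter). The other measured step lies elsewhere in the structure, placing 4-chloro-2-hydroxyphenyl where 2-hydroxy-3-methoxyphenyl stood, and it gives a 1.0-fold higher number from compound 1 to compound 2 (0.01 log units; within the scatter). Among the compounds with values here, neither step leaves the scatter, and the series so far offers no sign of a large response in this assay to either change. A step beyond the scatter is therefore not expected for the small addition here, and no direction can be argued from these data.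

The expected step is a 1.1-fold lower number from compound 1 to compound 4 (0.06 log units; within the scatter). For compound 4 the estimated value is 43000 nM, with an expected range of 23000 nM to 78000 nM.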

Compound 4, half-maximal cytotoxic concentration: 34500 nM
Estimate against measurement, compound 4: 1.2-fold (0.10 log units) above, within the range that was stated.
By their numbers in this assay, from the lowest: compounds 3, 4, 1 and 2 (each within the scatter of the next).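

In this assay the step from methoxy to ethoxy is a 1.4-fold lower number from compound 1 to compound 4 (0.15 log units; within the scatter), so adding a methyl on the saturated chain carbon bound to an oxygen on an aromatic ring does not separate the two compounds. Going by these compounds alone, this is the first step that changes this alkoxy group alone, with the 4-methoxyphenyl position retained and the 2-hydroxy-3-methoxyphenyl group on the carbonyl carbon held constant, whereas the earlier change at this ring replaced 4-methoxyphenyl with 3-methylphenyl and so altered both the group and its place. The data offer nothing that could account for the size of this step.

The compounds shown leave open whether a longer chain on this oxygen, such as propoxy or butoxy, or a chain ending in an amine or a carboxylic acid, would give a step beyond the scatter. They also leave open whether methoxy to ethoxy gives a step of similar size when 4-chloro-2-hydroxyphenyl stands on the carbonyl carbon.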